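Hydrazone Series Tested Against Liver Cancer Cells

This account rests on a few compounds, and the source may have more. Where it says the series, first, only, none or still open, it means among the compounds named here.

Measured compounds:
- compound 1, `O=C(N/N=C/c1ccco1)c1cccc(S(=O)(=O)N2CCOCC2)c1`: > 100000 nM
- compound 2, `CCN(CC)c1ccc(/C=N/NC(=O)c2cccc(S(=O)(=O)N3CCOCC3)c2)c(O)c1`: 27100 nM

Compound 1 gives only a limit in a functional assay on SMMC-7721 cells (Homo sapiens) for antiproliferative activity, read by MTT assay, with a stated time of 72 h (on this read-out higher numbers stand for weaker inhibition and lower numbers for stronger inhibition), reported as > 100000 nM. Among the measured compounds shown here, compound 2 is the only compound with a number in this assay, where it gives 27100 nM. The remaining value, that of compound 1, is a limit, as noted in the limit of > 100000 nM in this assay, at which 1 of the 2 values shown sits.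

Compound 3, `COc1ccc(/C=N/NC(=O)c2cccc(S(=O)(=O)N3CCOCC3)c2)c(O)c1`, has not been measured. It differs from compound 2 by methoxy in place of diethylamino on an aromatic carbon, meta to a hydroxy group and para to a large group. For the measured compounds named here, no step between two measured compounds speaks to this change, so the expected size cannot be taken from the data. The writer expects compound 3 to be somewhat weaker, with an estimated step of a 1.8-fold higher number from compound 2 to compound 3 (0.27 log units; within the scatter). Compound 3 is thus estimated at 50000 nM, within a range from 15000 nM to 150000 nM.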

Compound 3, half-maximal inhibitory concentration: 3950 nM
Estimate against measurement, compound 3: 13-fold (1.10 log units) above; the whole stated range lies above it.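

Among the compounds shown here, replacing diethylamino with methoxy on this aromatic carbon, para to a large group, gives a 6.9-fold lower number from compound 2 to compound 3 (0.84 log units; beyond the scatter) in this assay, which shows for the first time that the result depends on the group at this place, although both groups count 0 hydrogen-bond donors and 1 hydrogen-bond acceptor and differ in heavy atoms, 5 against 2. Replacing furan-2-yl with 2-hydroxy-4-methoxyphenyl gives an at least 25-fold lower number from compound 1 to compound 3 (1.40 log units; beyond the scatter), so the aromatic group on the carbon with a double bond to nitrogen matters as well. Compound 1 gives a limit and not a number, so that second step has no exact size: the limit of > 100000 nM in this assay, at which 1 of the 3 values shown sits.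

Going by these compounds, how a hydrogen, an ethoxy group or a dimethylamino group would fare on this aromatic carbon remains open. Also open, on these data alone, is how much of the step from the furan-2-yl compound belongs to the hydroxy group and how much to the methoxy group.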